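Aryl exchange on the amine nitrogen of the series

The source may hold more compounds than are shown below. What is called first, only, known or untested is meant among the compounds shown, and "the series" means these compounds.

Values in a functional assay on HeLa cells (Homo sapiens) for inhibition, read by sulforhodamine B assay; on this read-out higher numbers stand for weaker inhibition and lower numbers for stronger inhibition:
compound 1 `CCCc1ccc(NC2=CC(=O)c3nc4n(c3C2=O)[C@H]2OC[C@@H](O)[C@H]2OC4)cc1`: 4990 nM
compound 2 `O=C1C(Nc2ccccc2F)=CC(=O)c2c1nc1n2[C@H]2OC[C@@H](O)[C@H]2OC1`: 9820 nM
compound 3 `CCc1ccc(NC2=CC(=O)c3nc4n(c3C2=O)[C@H]2OC[C@@H](O)[C@H]2OC4)cc1`: 3990 nM

Compound 2 at 9820 nM lies within the scatter of compound 1, while its gap to compound 3 lies beyond the scatter, with compound 3 on the lower number. The unmeasured compound 4 `O=C1C(Nc2ccc(C(F)(F)F)cc2)=CC(=O)c2c1nc1n2[C@H]2OC[C@@H](O)[C@H]2OC1` differs from compound 2 as follows: 4-(trifluoromethyl)phenyl in place of 2-fluorophenyl on an amine nitrogen. This places 4-(trifluoromethyl)phenyl in place of 2-fluorophenyl on an amine nitrogen.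

Among the compounds with values here, only one measured step bears on this, and only indirectly: a 1.3-fold lower number from compound 1 to compound 3 (0.10 log units; within the scatter), which is within the scatter. Within the data shown here, no measured step makes this aryl exchange itself. In this assay a modest step toward a lower number is therefore expected, possibly none beyond the scatter. That lean rests on compound 1 at 4990 nM and compound 3 at 3990 nM, whose aryl groups also differ from 2-fluorophenyl. The expected step is a 1.8-fold lower number from compound 2 to compound 4 (0.25 log units; within the scatter). Compound 4 is estimated at 5500 nM, with an expected range from 2500 nM to 12000 nM.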

Compound 4, half-maximal inhibitory concentration: 8920 nM
Compound 4: the middle estimate sits 1.6-fold (0.21 log units) below what was measured; the measured number falls inside the stated range.
By their numbers in this assay, from the lowest: compounds 3, 1, 4 and 2 (each within the scatter of the next, the first and the last beyond it).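

In this assay the exchange of 2-fluorophenyl for 4-(trifluoromethyl)phenyl on the amine nitrogen gives a 1.1-fold lower number from compound 2 to compound 4 (0.04 log units; within the scatter) and so produces no readable change. Unlike the step between compound 1 and compound 3, which only shortens a chain on the aryl group, this step replaces one fluorine-bearing aryl group with a larger one, so the series now has a direct comparison between two different substituted aryl groups at this position. Nothing available offers an explanation for this flat result.

Still open, going by these compounds, is whether plain phenyl, with no substituent, would sit with compound 2 and compound 4 in this assay. On these data alone, it is also open whether an aryl group carrying a carboxylic acid or an amine, or a simple alkyl chain in place of the aryl group, would move the number beyond the scatter.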